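Three Hydroxyphenyl Pyridines Tested Against Topoisomerase 1

The source may report more compounds than this note shows. Statements on the series, on what has been measured and on what is new or still open speak of the compounds shown alone.

Measured compounds:
- compound 1, `Oc1cccc(-c2cc(-c3ccccc3O)nc(-c3ccccc3O)c2)c1`: 4.9%
- compound 2, `Oc1ccccc1-c1cc(-c2ccccc2O)nc(-c2ccccc2O)c1`: 0%
- compound 3, `Oc1ccc(-c2cc(-c3ccccc3O)cc(-c3ccccc3O)n2)cc1`: 0.3%

All three compounds share a core carrying three hydroxyphenyl groups, and all were tested in an assay on isolated protein for inhibition of DNA topoisomerase 1 (Homo sapiens), with a stated time of 30 min, tested at 100 uM; a higher number here means more inhibition at the concentration tested (going by the name of the read-out), a lower number less inhibition. In this assay compound 2 gives 0%, compound 1 gives 4.9% and compound 3 gives 0.3%. Compound 1 arises from compound 2 by 3-hydroxyphenyl in place of 2-hydroxyphenyl on an aromatic carbon, which gave a number 4.9 percentage points higher from compound 2 to compound 1 (within the scatter). Compound 3 arises from compound 2 by 4-hydroxyphenyl in place of 2-hydroxyphenyl on an aromatic carbon, which gave a number 0.3 percentage points higher from compound 2 to compound 3 (within the scatter). Neither step leaves the scatter, so the three values cannot be ordered.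

Compound 4, `Oc1ccc(-c2cc(-c3cccc(O)c3)cc(-c3ccccc3O)n2)cc1`, has not yet been measured. It arises from compound 3 by 3-hydroxyphenyl in place of 2-hydroxyphenyl on an aromatic carbon. This is the same kind of change as that from compound 2 to compound 1, though its surroundings differ: in compound 3 the place is meta to a 2-hydroxyphenyl group and meta to a 4-hydroxyphenyl group, whereas in compound 2 it is meta to two 2-hydroxyphenyl groups. The step from compound 3 to compound 4 is expected to be a number 3.7 percentage points higher from compound 3 to compound 4 (within the scatter), resting on the earlier step of a number 4.9 percentage points higher from compound 2 to compound 1 (within the scatter), which stayed within the scatter. Compound 4 is therefore estimated at 4%, with a likely range from 0% to 14%.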

Compound 4, a percentage reported as inhibition, at one concentration (the size of the read-out at that concentration, not a potency): 8.4%
The estimate for compound 4 lay 4.4 percentage points below the measured number, and the stated range covers the measured number.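

In this assay, putting 3-hydroxyphenyl in place of 2-hydroxyphenyl gave a number 8.1 percentage points higher from compound 3 to compound 4 (within the scatter), and this step can be set beside the same change on another core: the same change on two cores in this assay, a number 4.9 percentage points higher (within the scatter) from compound 2 to compound 1 and a number 8.1 percentage points higher (within the scatter) from compound 3 to compound 4, 3.2 percentage points apart, within the scatter of two such steps. Putting 4-hydroxyphenyl in place of 2-hydroxyphenyl gave a number 3.5 percentage points higher from compound 1 to compound 4 (within the scatter), and this step can likewise be compared with its earlier counterpart: the same change on two cores in this assay, a number 0.3 percentage points higher (within the scatter) from compound 2 to compound 3 and a number 3.5 percentage points higher (within the scatter) from compound 1 to compound 4, 3.2 percentage points apart, within the scatter of two such steps. Neither change therefore shows any measurable difference from one core to the other, but with every step inside the scatter, the data do not show that either change really alters inhibition, so there is no clear effect that can be said to carry over.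

The compounds shown differ only in which hydroxyphenyl groups they carry, which leaves open how this assay would respond if a different group, such as an amine or a carboxylic acid, took the place of the hydroxyl on these rings. Going by these compounds, it also remains open whether any compound built on this core can give inhibition that stands clearly beyond the scatter from the others.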